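A few compounds are considered here, and "the series" means these few. Any claim that something is new, unique, unknown or untested is made for them only; others in the source may bear on it.

In a functional assay on NCI-H522 cells (Homo sapiens) for cytotoxicity, read by sulforhodamine B assay, with a stated time of 48 h (on this read-out higher numbers stand for lower toxicity in this test and lower numbers for higher toxicity in this test), compound 1 `ClCc1cccc(Cn2cnc3ncnc(Cl)c32)c1` gives > 100000 nM, which is a limit of the test rather than a number. Compound 1 therefore stands at the limit of > 100000 nM in this assay, at which 1 of the 3 values shown sits, and nothing more exact is known for it. Two related compounds do give numbers: compound 2 `ClCc1ccc(Cn2cnc3nc(Cl)nc(Cl)c32)cc1` gives 38000 nM, and compound 3 `ClCc1ccc(Cn2cnc3c(Cl)nc(Cl)nc32)cc1` gives 97700 nM in this assay. Compound 4 `ClCc1cccc(Cn2cnc3nc(Cl)nc(Cl)c32)c1` has not been measured. It differs from compound 1 by chloro in place of hydrogen on an aromatic carbon, a chloro in place of hydrogen on an aromatic carbon, between two ring nitrogen atoms. Going by the values given here, no measured pair shows the size of this change on its own. The expectation leans on compound 2, which carries the same added chloro and gives 38000 nM. A move toward higher toxicity, somewhat beyond the scatter, is expected as an at least 1.8-fold lower number from compound 1 to compound 4 (0.25 log units; that floor lies within the scatter). Compound 4 is estimated at 55000 nM, within 20000 nM to 150000 nM.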

Compound 4, concentration lethal to 50% of the cells: 6910 nM
Compound 4: middle estimate off by 8.0-fold (0.90 log units), on the high side, outside the stated range (below it).
By their numbers in this assay, from the lowest: compound 4; then compound 2; then compound 3. At a limit, above all of these: compound 1.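

In this assay the chloro in place of hydrogen on an aromatic carbon, between two ring nitrogen atoms, gives an at least 14-fold lower number from compound 1 to compound 4 (1.16 log units; beyond the scatter) and so moves the read-out toward higher toxicity, beyond the scatter. Going by these compounds alone, this is the first measured pair that isolates this single change, and it shows that this position responds to one added chlorine atom. The step is only a minimum, because the value of compound 1 is a limit and not a number: the limit of > 100000 nM in this assay, at which 1 of the 4 values shown sits.

On these data alone, whether an amine or a methoxy group at this position would give a step of similar size remains open. So does whether a chloro at other positions on the core of compound 1 would have a similar effect.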